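Swapping phenyl for pyridin-4-yl on the imide nitrogen

The source may report more compounds than this note shows. Statements on the series, on what has been measured and on what is new or still open speak of the compounds shown alone.

The measured compounds are:
- compound 1, `CN(C)c1ccc(N2C(=O)NC3(CSC4=C3C(=O)c3ncccc3C4=O)C2=O)cc1`: 20 nM
- compound 2, `O=C1NC(=O)C2(CSC3=C2C(=O)c2ncccc2C3=O)N1`: 190 nM; 180 nM; 190 nM (3 entries)
- compound 3, `O=C1C2=C(C(=O)c3ncccc31)C1(CS2)NC(=O)N(c2ccccc2)C1=O`: 2 nM

These three share a core and differ only in what sits on the amide-type nitrogen of the five-membered ring. In a functional assay on HT-29 cells (Homo sapiens) for antiproliferative activity, read by MTT assay, with a stated time of 96 h (a lower number here means a stronger inhibitor, a higher number a weaker inhibitor), compound 3 gives 2 nM, the lowest of the two single numbers; the nearest, compound 1, gives 20 nM. Compound 2 has no single number but several entries, (the several entries of compound 2 in this assay, 190 nM; 180 nM; 190 nM (3 entries)), which agree closely with one another.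

Among the measured compounds shown here, the one step between measured compounds is a 10-fold lower number from compound 1 to compound 3 (1.00 log units; beyond the scatter). It shows that what is attached to the aryl ring on this nitrogen can move the result by a clear margin, but it concerns a substituent on the ring, not the ring itself.

Compound 4, `O=C1C2=C(C(=O)c3ncccc31)C1(CS2)NC(=O)N(c2ccncc2)C1=O`, changes the ring: pyridin-4-yl in place of phenyl on an amide-type nitrogen in a ring. For the measured compounds named here, no measured step covers this exchange, so the expectation rests on compound 3 alone, with room for movement in either direction. Compound 4 is expected to give 3 nM, between 0.8 nM and 12 nM, which would be a 1.5-fold higher number from compound 3 to compound 4 (0.18 log units; within the scatter), within the scatter.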

Compound 4, half-maximal inhibitory concentration: 2 nM
Compound 4: the middle estimate sits 1.5-fold (0.18 log units) above what was measured; measured number inside the range.
By their numbers in this assay, from the lowest: compounds 3 and 4 (each within the scatter of the next); then compound 1.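

In this assay, replacing phenyl with pyridin-4-yl on this amide-type nitrogen in a ring gives a clear reading (no change at the digits printed from compound 3 to compound 4 (within the scatter)). The earlier step showed only that a substituent on the aryl ring can move the result, whereas this one shows that a ring carbon of that aryl ring can give way to a nitrogen, bringing in a hydrogen-bond acceptor, with no movement beyond the scatter. The step from the dimethylamino compound is the same in size as the earlier one (a 10-fold lower number from compound 1 to compound 4 (1.00 log units; beyond the scatter)), so compound 4 stands apart from compound 1 just as compound 3 does, although nothing given here accounts for why the exchange of phenyl for pyridin-4-yl leaves the number in place.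

The compounds shown leave open whether the ring nitrogen can sit elsewhere in the ring, as it does in pyridin-3-yl or pyridin-2-yl. They also leave open whether the pyridine ring would keep this number if it carried a substituent such as an amine or a carboxylic acid.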